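Coumarin amine series: ring size of the basic amine

The source may report more compounds than this note shows. Statements on the series, on what has been measured and on what is new or still open speak of the compounds shown alone.

Measured so far:
compound 1 `COc1cc2ccc(=O)oc2cc1OCC(O)CN1CCN(C)CC1` — 3.4%
compound 2 `COc1cc2ccc(=O)oc2cc1OCC(O)CN1CCCC1` — 0.3%

In a functional assay on HUVEC cells (Homo sapiens) for inhibition, read by MTT assay, with a stated time of 24 h, tested at 100 uM (a higher number here means more inhibition of growth at the concentration tested, a lower number less inhibition of growth), compound 1 gives 3.4%; compound 2 gives 0.3%. Going by the values given here, the two numbers sit within the scatter of each other, and the step of a number 3.1 percentage points lower from compound 1 to compound 2 (within the scatter) is the only measured step. Compound 2 thus stands at a number indistinguishable from compound 1.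

Compound 3 `COc1cc2ccc(=O)oc2cc1OCC(O)CN1CCCCC1` is not yet measured. It differs from compound 2 by piperidin-1-yl in place of pyrrolidin-1-yl on a saturated chain carbon, two bonds along the chain from an oxygen on a saturated carbon. Among the compounds with values here, the one step that bears on this change, a number 3.1 percentage points lower from compound 1 to compound 2 (within the scatter), swapped the amine ring at the same place and stayed within the scatter; it gives no sign that the amine ring moves the read-out. The expectation for compound 3 in this assay is therefore no step beyond the scatter, a number 1.7 percentage points higher from compound 2 to compound 3 (within the scatter). Compound 3 is estimated at 2%, with a range from -8% to 12%.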

Compound 3, percent growth inhibition at one concentration: 80.7%
Beside the measured number, compound 3's estimate is 78.7 percentage points below it; measured number outside the range, above it.
By their numbers in this assay, from the lowest: compounds 2 and 1 (each within the scatter of the next); then compound 3.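

In this assay, the amine ring at this place can move the read-out far beyond the scatter: a number 80.4 percentage points higher from compound 2 to compound 3 (beyond the scatter) with piperidin-1-yl in place of pyrrolidin-1-yl, and a number 77.3 percentage points higher from compound 1 to compound 3 (beyond the scatter) with piperidin-1-yl in place of 4-methylpiperazin-1-yl. The earlier step between compound 1 and compound 2 gave no sign of this, and ring size alone does not sort the three, as compound 1 also carries a six-membered ring yet stays within the scatter of compound 2. Nothing measured here bears on why piperidin-1-yl stands apart.

The compounds shown leave open whether morpholin-4-yl or azepan-1-yl at this place would group with compound 3 or with compound 1 and compound 2. They also leave open how the read-out of compound 3 behaves at lower concentrations.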